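Removing a methoxy group from a bromoacrylamide series

This account rests on a few compounds, and the source may have more. Where it says the series, first, only, none or still open, it means among the compounds named here.

Compound 1 `C=C(Br)C(=O)Nc1cccc(-c2cn3nc(Cc4ccc(OC)cc4)sc3n2)c1` gives 2300 nM in a functional assay on CCRF-CEM cells (Homo sapiens) for inhibition, read by cell counting, with a stated time of 3 days (on this read-out higher numbers stand for weaker inhibition and lower numbers for stronger inhibition), the lowest of the two numbers recorded here. Compound 2 `Nc1cccc(-c2cn3c(-c4ccccc4)csc3n2)c1` gives 29000 nM in this assay, a value that stands beyond the scatter from that of compound 1. For compound 3 `Nc1cccc(-c2cn3nc(-c4ccc(Cl)cc4)sc3n2)c1` this assay returns only a limit, > 250000 nM; (the limit of > 250000 nM in this assay, at which 1 of the 3 values shown sits). Compound 4 `C=C(Br)C(=O)Nc1cccc(-c2cn3nc(Cc4ccccc4)sc3n2)c1` has not yet been measured in this assay. It differs from compound 1 by hydrogen in place of methoxy on an aromatic carbon. Within the data shown here, no measured pair in this set carries the same change, so the expectation rests on compound 1 alone. Compound 4 is expected to sit close to compound 1, with an expected step of a 1.4-fold higher number from compound 1 to compound 4 (0.14 log units; within the scatter) that is small and, if anything, toward a slightly higher number. The estimate for compound 4 is 3200 nM, with a range from 1100 nM to 9500 nM.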

Compound 4, half-maximal inhibitory concentration: 4200 nM
For compound 4 the middle estimate is 1.3-fold (0.12 log units) below the measured one, within the range that was stated.
By their numbers in this assay, from the lowest: compounds 1 and 4 (each within the scatter of the next); then compound 2. At a limit, above all of these: compound 3.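

In this assay, among these compounds, going from 4-methoxybenzyl to benzyl gives a 1.8-fold higher number from compound 1 to compound 4 (0.26 log units; within the scatter), so at this place, para to a large group, the read-out tolerates the loss of the methoxy group, the first such comparison in this set. Nothing measured here accounts for this result. The compounds shown leave open whether an amine or a carboxylic acid at the same place would also stay within the scatter of compound 1. Among the compounds shown here, they also leave open what the bromoacrylamide contributes, as no pair differs in that group alone.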